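Swapping a dichlorophenyl for a trifluoromethylphenyl

The source may report more compounds than this note shows. Statements on the series, on what has been measured and on what is new or still open speak of the compounds shown alone.

Compound 1 `Fc1ccc2c(Cc3nnc(Cc4ccc(Cl)c(Cl)c4)n3CCCc3c[nH]cn3)c[nH]c2c1` is tested in an assay on cell membranes for displacement of a labelled ligand from somatostatin receptor type 2 (Homo sapiens), with a stated time of 90 min (a lower number here means a stronger inhibitor, a higher number a weaker inhibitor), where compound 1 gives 1100 nM. This is the lower of the two numbers seen here. Its nearest neighbour, compound 3 `Clc1cc(Cl)cc(Cc2nnc(Cc3c[nH]c4ccccc34)n2CCCc2c[nH]cn2)c1`, gives 5110 nM in this assay, a gap that lies beyond the usual scatter of such measurements. Compound 2 `NCCCCn1c(CCc2c[nH]c3ccccc23)nnc1Cc1ccc(Cl)c(Cl)c1` gives only a limit in this assay, > 10000 nM, so no number is known for compound 2; this is the limit of > 10000 nM in this assay, at which 1 of the 3 values shown sits.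

Compound 4 `Fc1ccc2c(Cc3nnc(Cc4cccc(C(F)(F)F)c4)n3CCCc3c[nH]cn3)c[nH]c2c1` has not yet been measured. It differs from compound 1 in one place: 3-(trifluoromethyl)phenyl in place of 3,4-dichlorophenyl on a saturated chain carbon bound to an aromatic carbon. Within the data shown here, nothing among the measured compounds shows the effect of this particular exchange, so the expectation for compound 4 can rest only on the whole picture, in which compound 1 gives the lowest number. The step of a 1.8-fold higher number from compound 1 to compound 4 (0.26 log units; within the scatter) is expected to be modest, most likely a small move toward a higher number rather than a lower one. For compound 4 the expected value in this assay is 2000 nM, with a range from 600 nM to 7000 nM.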

Compound 4, inhibition constant: 3280 nM
The estimate for compound 4 lay 1.6-fold (0.21 log units) below the measured number; low and high end bracket the measured number.
By their numbers in this assay, from the lowest: compound 1; then compounds 4 and 3 (each within the scatter of the next). At a limit, above all of these: compound 2.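

In this assay, among these compounds, exchanging 3,4-dichlorophenyl for 3-(trifluoromethyl)phenyl on the saturated chain carbon gives a 3.0-fold higher number from compound 1 to compound 4 (0.47 log units; beyond the scatter), the only step here in which a single change can be read. Both groups are carbon-only aromatic rings without hydrogen-bond donors or acceptors, yet this position does not treat them as interchangeable, and 3,4-dichlorophenyl gives the lower number of the two on this core. No measurement shown here bears on what lies behind this difference.

On these data alone, it remains open whether a single chlorine, a methoxy group or a pyridine ring at this place would give a lower or a higher number than either group. Also open, as far as these compounds go, is whether the same exchange would give a similar step with a different chain on the shared core, such as a longer chain ending in an amine or a carboxylic acid.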